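The source may report more compounds than this note shows. Statements on the series, on what has been measured and on what is new or still open speak of the compounds shown alone.

Measured compounds:
- compound 1 `COc1cc2c(cc1OC)C(CC(=O)Nc1ccc(Br)cc1)CC2`: 46.3%
- compound 2 `COc1ccccc1NC(=O)CC1CCc2cc(OC)c(OC)cc21`: 24.1%

In a functional assay on the whole organism (strain Wistar) for inhibition, with Rattus norvegicus as the target, read by paw edema, with a stated time of 6 h, at a dose of 100 mg/kg (on this read-out higher numbers stand for more inhibition at the one dose given (going by the name of the read-out) and lower numbers for less inhibition), compound 1 gives 46.3%. Compound 2, with a 2-methoxyphenyl on the amide nitrogen, gives 24.1% in this assay, the lower of the two numbers shown, and the step of a number 22.2 percentage points lower from compound 1 to compound 2 (beyond the scatter) lies beyond the scatter. Compound 3 `COc1cc2c(cc1OC)C(CC(=O)Nc1cccnc1)CC2` differs from compound 2 in one place: pyridin-3-yl in place of 2-methoxyphenyl on an amide-type nitrogen. Within the data shown here, the only measured step, the one from compound 1 to compound 2 with its drop of a number 22.2 percentage points lower from compound 1 to compound 2 (beyond the scatter), concerns a different pair of groups and bears on the present change only in showing that swapping the group on the amide nitrogen can move the read-out by a modest amount in this assay. Since compound 2 sits at the low end, a step in this assay of about a number 10.9 percentage points higher from compound 2 to compound 3 (beyond the scatter) upward is expected for compound 3, with little certainty. Compound 3 is therefore estimated at 35%, likely between 15% and 55%.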

Compound 3, a percentage reported as inhibition, in the whole organism at one dose (the size of the read-out at that dose, not a potency): 35.2%
Compound 3: middle estimate off by 0.2 percentage points, on the low side; measured number inside the range.
By their numbers in this assay, from the lowest: compound 2; then compound 3; then compound 1.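

In this assay the pyridin-3-yl group on the amide-type nitrogen gives a step of a number 11.1 percentage points higher from compound 2 to compound 3 (beyond the scatter) against the 2-methoxyphenyl group and a step of a number 11.1 percentage points lower from compound 1 to compound 3 (beyond the scatter) against the 4-bromophenyl group. The position now holds three groups with three numbers set apart beyond the scatter, and the six-membered aromatic ring with a hetero atom sits in the middle rather than at either end. Replacing a ring of carbon only with this ring therefore has no single direction here: the sign of the step depends on which carbon ring it replaces.

On these data alone, whether an unsubstituted phenyl, a pyridin-4-yl or a benzyl group on the amide-type nitrogen would fit this order remains open. Nothing measured here speaks to why the three groups fall in this order.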